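Lengthening a Short Chain on a Shared Core

The source may report more compounds than this note shows. Statements on the series, on what has been measured and on what is new or still open speak of the compounds shown alone.

Compound 1 `C/N=C(\NC#N)NCCSCn1nc(-c2ccccc2)ccc1=O` — in a functional assay on the whole organism (stomach) for inhibition, with Rattus norvegicus as the target, with a stated time of 4 h (a lower number here means that less compound is needed, a higher number that more compound is needed for the effect), compound 1 gives only a limit, < 30.5 mg/kg, not a number.
Compound 2 `CC/N=C(\NC#N)NCCSCn1nc(-c2ccccc2)ccc1=O` — in this assay compound 2 likewise gives only a limit, < 100 mg/kg.

Compound 2 therefore stands on nothing firmer than the limit of < 100 mg/kg in this assay, at which 1 of the 2 values shown sits; no exact figure for it is known. Compound 3 `CCC/N=C(\NC#N)NCCSCn1nc(-c2ccccc2)ccc1=O` differs from compound 2 by methyl in place of hydrogen on a saturated chain carbon, two bonds along the chain from a double-bonded nitrogen. Among the measured compounds shown here, the only measured step that bears on this change is a step that the two limits leave unreadable from compound 1 to compound 2. Because one of its ends rests on the limit of < 30.5 mg/kg in this assay, at which 1 of the 2 values shown sits, and the other on (the limit of < 100 mg/kg in this assay, at which 1 of the 2 values shown sits), neither its size nor its direction can be read from the two values. The shown data thus give no ground to expect a step beyond the usual scatter in either direction, and the result for compound 3 may well again come back as a limit rather than a number. On that basis compound 3 is expected to give about 30 mg/kg, with a range from 5 mg/kg to 100 mg/kg. This estimate amounts to an expected step that the limit leaves unreadable from compound 2 to compound 3.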

Compound 3, dose for half-maximal effect: > 100 mg/kg
Compound 3: a limit, no number; the forecaster's own chance of this, stated with the estimate: 60%; middle value at least 3.3-fold (0.52 log units) away from the limit.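

Among the compounds shown here, until now, no step at this position could be read; the first one now stands in this assay (an at least 3.2-fold higher number from compound 1 to compound 3 (0.51 log units; beyond the scatter)), while the single added methyl gives only a step of open size (a number no lower from compound 2 to compound 3 (the limit leaves the size open)). Together these show that the length of this short chain matters, with more compound needed for the effect once the chain reaches propyl. The sizes of the two single methyl steps stay unreadable, however, so the change cannot be assigned to either added methyl, because compound 2, which lies on both of them, rests only on a limit: the limit of < 100 mg/kg in this assay, at which 1 of the 3 values shown sits.

The compounds shown leave open how much compound 3 really needs and whether compound 2 sits closer to compound 1 or to compound 3, since exact numbers would be needed to place them. They also leave open whether a longer chain such as butyl would behave like propyl, and whether a hydroxyl or an amine at the end of the chain would change the result in this assay.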